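The source may hold more compounds than are shown below. What is called first, only, known or untested is meant among the compounds shown, and "the series" means these compounds.

Measured so far:
- compound 1, `Cc1nn(C)c(Oc2ccc(F)cc2)c1/C=N\CCCCCOc1cc2oc(=O)cc(C)c2cc1Cl`, in a functional assay on U-87MG ATCC cells for antiproliferative activity against U-87 MG (Homo sapiens), read by MTT assay, with a stated time of 72 h (on this read-out higher numbers stand for weaker inhibition and lower numbers for stronger inhibition), gives > 25000 nM, which is a limit of the assay rather than a number.
- compound 2, `Cc1nn(C)c(Oc2ccc(Br)cc2)c1/C=N\CCCCCOc1cc2oc(=O)cc(C)c2cc1Cl`, gives 15300 nM.
- compound 3, `Cc1nn(C)c(Oc2cccc(F)c2F)c1/C=N\CCCCCCOc1cc2oc(=O)cc(C)c2cc1Cl`, gives > 25000 nM, again a limit of the assay and not a number.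

Compound 3 therefore stands at the edge of what this assay can report, and this is the common situation here: the limit of > 25000 nM in this assay, at which 2 of the 3 values shown sit. For the measured compounds named here, the one measured step between neighbours, an at least 1.6-fold lower number from compound 1 to compound 2 (0.21 log units; that floor lies within the scatter), replaces fluoro with bromo on an aromatic carbon, and its size lies within the scatter, so it shows no clear direction.

Compound 4, `Cc1ccc(Oc2c(/C=N\CCCCCCOc3cc4oc(=O)cc(C)c4cc3Cl)c(C)nn2C)cc1`, differs from compound 3 by 4-methylphenyl in place of 2,3-difluorophenyl on an oxygen on an aromatic ring. Going by the values given here, no measured step covers this kind of change; the only step on record concerns bromo in place of fluoro, not the exchange of the whole phenyl group. Among the compounds with values here, with compound 3 sitting at the limit and the single measured step within the scatter, no movement beyond the scatter is expected in this assay, in either direction. The step this estimate means, a number no higher from compound 3 to compound 4 (the limit leaves the size open), is expected to stay within the scatter. For compound 4 the expected value in this assay is 25000 nM, within a range from 10000 nM to 60000 nM.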

Compound 4, half-maximal inhibitory concentration: 23600 nM
Beside the measured number, compound 4's estimate is 1.1-fold (0.03 log units) above it; measured number inside the range.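

Set against the earlier bromo-for-fluoro step, this result concerns a larger change: the whole group on the oxygen on an aromatic ring is exchanged, with 4-methylphenyl in place of 2,3-difluorophenyl. In this assay, this exchange gives an at least 1.0-fold lower number from compound 3 to compound 4 (0.02 log units; that floor lies within the scatter). It therefore shows no clear move in either direction, even though the entering group carries no fluorine and brings a methyl group onto the ring. Compound 4 does give a real number, 23600 nM. The true size of the step cannot be read, as compound 3 stands at a limit of the assay, and such a limit is common among these compounds: the limit of > 25000 nM in this assay, at which 2 of the 4 values shown sit.

The compounds shown leave open whether this position can move the number clearly at all, since they do not say how a phenoxy group carrying an amine or a carboxylic acid would behave in this assay. They also leave open what a longer chain would do, and a step with a real number at both ends is still needed to give the size of any such change.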